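Working notes: from compound 2 to compound 3

The compounds below may be only part of what the source reports. "The series", "measured", "known", "first", "only" and "open" are said of these compounds alone.

Compound 1 `CC(C)CN(Cc1ccc(N2CCN(S(C)(=O)=O)CC2)cc1)S(=O)(=O)Cc1ccccc1` and compound 2 `CC(=O)N1CCN(c2ccc(CN(CC(C)C)S(=O)(=O)Cc3ccccc3)cc2)CC1` differ in one place. In a physicochemical assay for solubility, in phosphate buffer, measured as kinetic solubility, with a stated time of 24 h, at pH 7.4 (on this read-out lower numbers stand for lower solubility and higher numbers for higher solubility), compound 1 gives <= 1000 nM as its result, and this is a limit of the assay. In this assay compound 2 gives <= 1000 nM as its result, and this too is a limit. Among the measured compounds shown here, the one measured step, a step that the two limits leave unreadable from compound 1 to compound 2 with acetyl in place of methylsulfonyl on an amine nitrogen in a ring, therefore has no readable size. The evidence amounts to the limit of <= 1000 nM in this assay, at which 2 of the 2 values shown sit, and nothing more, so compound 2 stands at a limit and not at a number.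

Compound 3 `CC(=O)N1CCN(c2ccc(CN(CCN(C)C)S(=O)(=O)Cc3ccccc3)cc2)CC1` carries the change (dimethylamino)methyl in place of isopropyl on a saturated chain carbon bound to a sulfonamide nitrogen with (dimethylamino)methyl in place of isopropyl on a saturated chain carbon bound to a sulfonamide nitrogen. For the measured compounds named here, no measured step touches this place, so the expectation rests on the structural change alone and stays loose. The expected step is an at least 15-fold higher number from compound 2 to compound 3 (1.17 log units; beyond the scatter) and its expected direction is upward. In this assay the estimate for compound 3 is 15000 nM with an expected range from 1000 nM to 100000 nM on this solubility read-out.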

Compound 3, solubility: 221000 nM
For compound 3 the middle estimate is 15-fold (1.17 log units) below the measured one; measured number above the stated range.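

In this assay, among the compounds shown here, (dimethylamino)methyl in place of isopropyl on a saturated chain carbon bound to a sulfonamide nitrogen gives an at least 220-fold higher number from compound 2 to compound 3 (2.34 log units; beyond the scatter), the only readable step so far. Compound 2 stands at a limit, so this step marks a lower bound on the size of the change and not its full size: the limit of <= 1000 nM in this assay, at which 2 of the 3 values shown sit. The step between compound 1 and compound 2 cannot be read, whereas the change on the chain takes compound 3 clear of the limit and makes this position, unlike the acetyl and methylsulfonyl position on the ring nitrogen, one where a change has a visible result.

The compounds shown leave open whether the higher number depends on the dimethylamino nitrogen itself or would also appear with a 2-methoxyethyl group, another amine such as pyrrolidine, a carboxylic acid or a longer chain at this place. For the compounds shown here, also open is whether the step carries over to the methylsulfonyl compound, since this change is seen only with acetyl on the ring nitrogen.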